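From phenyl to cyclopropyl on the ring nitrogen

This account rests on a few compounds, and the source may have more. Where it says the series, first, only, none or still open, it means among the compounds named here.

Compound 3 `O=C1COc2ccc(-c3cccc(NS(=O)(=O)c4ccc(F)cc4)c3)cc2N1c1ccccc1` gives only a limit in a functional assay on HCT-116 cells (Homo sapiens) for antiproliferative activity, read by MTT assay, with a stated time of 72 h (a lower number here means a stronger inhibitor, a higher number a weaker inhibitor), > 40000 nM, and so stands at the limit of > 40000 nM in this assay, at which 1 of the 3 values shown sits. With isopropyl on the amide-type nitrogen, compound 1 `CC(C)N1C(=O)COc2ccc(-c3cccc(NS(=O)(=O)c4ccc(F)cc4)c3)cc21` gives 22600 nM. With 4-chlorophenyl there, compound 2 `O=C1COc2ccc(-c3cccc(NS(=O)(=O)c4ccc(F)cc4)c3)cc2N1c1ccc(Cl)cc1` gives 23900 nM, and the two are linked by a 1.1-fold higher number from compound 1 to compound 2 (0.02 log units; within the scatter).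

Compound 4 `O=C1COc2ccc(-c3cccc(NS(=O)(=O)c4ccc(F)cc4)c3)cc2N1C1CC1` carries cyclopropyl in place of phenyl on that nitrogen: cyclopropyl in place of phenyl on an amide-type nitrogen in a ring. The nearest guides are an at least 1.7-fold higher number from compound 1 to compound 3 (0.24 log units; that floor lies within the scatter) and an at least 1.6-fold higher number from compound 2 to compound 3 (0.22 log units; that floor lies within the scatter), and both give only a floor. Read in reverse, the first suggests a modest move towards a lower number, close to the scatter. The expected size is an at least 1.5-fold lower number from compound 3 to compound 4 (0.18 log units; that floor lies within the scatter). Compound 4 is estimated at 26000 nM, with an expected range from 12000 nM to 40000 nM.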

Compound 4, half-maximal inhibitory concentration: > 40000 nM
Compound 4: a limit, no number; the forecaster's own chance of this, stated with the estimate: 35%; middle value at least 1.5-fold (0.18 log units) from the limit.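

Compound 4 gives only a limit, as compound 3 does, so the step between them cannot be read and cyclopropyl in place of phenyl brings no measurable gain on this nitrogen: the limit of > 40000 nM in this assay, at which 2 of the 4 values shown sit. The readable steps are an at least 1.7-fold higher number from compound 1 to compound 4 (0.24 log units; that floor lies within the scatter) and an at least 1.6-fold higher number from compound 2 to compound 4 (0.22 log units; that floor lies within the scatter). Both are only floors, so cyclopropyl cannot be placed relative to isopropyl or 4-chlorophenyl beyond that.

Still open, from the compounds shown here alone, is whether an amine, a carboxylic acid or a longer chain on this nitrogen would give a real number rather than a limit.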